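A few compounds are considered here, and "the series" means these few. Any claim that something is new, unique, unknown or untested is made for them only; others in the source may bear on it.

Compound 1 `CC(=O)OC/C1=C/C[C@](C)(CCC=C(C)C)/C=C/[C@@H](OC(=O)C=C(C)C)[C@](C)(O)/C=C/C1=O`: 2950 nM
Compound 2 `CCN(CC)C/C1=C/C[C@](C)(CCC=C(C)C)/C=C/[C@@H](OC(=O)C=C(C)C)[C@](C)(O)/C=C/C1=O`: 140 nM
Compound 3 `CC(C)=CCC[C@]1(C)/C=C/[C@@H](OC(=O)C=C(C)C)[C@](C)(O)/C=C/C(=O)/C(CN(C(C)C)C(C)C)=C\C1`: 740 nM

In a functional assay on HL-60 cells (Homo sapiens) for antiproliferative activity, read by MTT assay, with a stated time of 48 h (on this read-out lower numbers stand for stronger inhibition and higher numbers for weaker inhibition), compound 3 sits in the middle of the three, at 740 nM. The next structure is compound 4 `CC[Si](CC)(CC)C/C1=C/C[C@](C)(CCC=C(C)C)/C=C/[C@@H](OC(=O)C=C(C)C)[C@](C)(O)/C=C/C1=O`, and its change from compound 3 is a group of 7 heavy atoms (6 carbon, 1 silicon; no ring) in place of a group of 7 heavy atoms (6 carbon, 1 nitrogen; no ring), on a saturated chain carbon bound to a double-bonded ring carbon. Three measured steps at this same place bear on that change. Replacing acetoxy with diethylamino gave a 21-fold lower number from compound 1 to compound 2 (1.32 log units; beyond the scatter), and replacing it with diisopropylamino gave a 4.0-fold lower number from compound 1 to compound 3 (0.60 log units; beyond the scatter). Swapping one amino group for the other gave a 5.3-fold higher number from compound 2 to compound 3 (0.72 log units; beyond the scatter). The number therefore responds clearly to what sits here. Both lower numbers came with a nitrogen-bearing group, whereas the group entering compound 4 holds silicon in place of nitrogen. Among the measured compounds shown here, no measured compound carries this group, so these steps offer only indirect guidance. Compound 1, which has no amino group, gives 2950 nM and marks the weaker end. A modest move towards that end therefore seems likely in this assay. The expected change is a 2.2-fold higher number from compound 3 to compound 4 (0.33 log units; beyond the scatter). For compound 4 the estimate is 1600 nM, with an expected range from 400 nM to 5000 nM.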

Compound 4, half-maximal inhibitory concentration: 2810 nM
For compound 4 the middle estimate is 1.8-fold (0.24 log units) below the measured one; low and high end bracket the measured number.
By their numbers in this assay, from the lowest: compound 2; then compound 3; then compounds 4 and 1 (each within the scatter of the next).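

In this assay, the group of 7 heavy atoms holding silicon gives a 3.8-fold higher number from compound 3 to compound 4 (0.58 log units; beyond the scatter), even though diisopropylamino, the group it replaces, has the same count of heavy atoms, so the count alone does not set the number at this position. The same group gives a 20-fold higher number from compound 2 to compound 4 (1.30 log units; beyond the scatter), and it gives a 1.0-fold lower number from compound 1 to compound 4 (0.02 log units; within the scatter), which places it level with acetoxy, a group with no nitrogen. Among these four compounds, only the two carrying an amino group, compound 2 and compound 3, stand clearly lower, and none of the four goes against this. No measurement is available that explains this difference. As far as these compounds go, whether other amines, such as the ring-containing piperidine or the smaller dimethylamino, would also give low numbers here remains open.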